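A Larger Aromatic Group on a Weak Inhibitor

The source may hold more compounds than are shown below. What is called first, only, known or untested is meant among the compounds shown, and "the series" means these compounds.

In an ADME assay on MRC5 cells (Homo sapiens), read by MTT assay, with a stated time of 72 h (on this read-out lower numbers stand for stronger inhibition and higher numbers for weaker inhibition), compound 1 `CN(C)c1ncnc2c1c(-c1ccoc1)cn2[C@@H]1O[C@H](CO)[C@@H](O)[C@H]1O` gives > 100000 nM, which is a limit of the assay and not a number. Compound 2 `Nc1nc(N)c2c(-c3ccco3)cn([C@@H]3O[C@H](CO)[C@@H](O)[C@H]3O)c2n1` gives > 100000 nM, also a limit. Within the data shown here, compound 3 `COc1nc(N)nc2c1c(-c1ccco1)cn2[C@@H]1O[C@H](CO)[C@@H](O)[C@H]1O` gives 89700 nM, the only true number among the three. Among the measured compounds shown here, the one measured step, methoxy in place of amino on an aromatic carbon, is an at least 1.1-fold lower number from compound 2 to compound 3 (0.04 log units; that floor lies within the scatter). That step is only a floor, resting on (the limit of > 100000 nM in this assay, at which 2 of the 3 values shown sit), and it concerns a different group, so it offers little guidance here.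

Compound 4 `COc1nc(N)nc2c1c(-c1cc3ccccc3o1)cn2[C@@H]1O[C@H](CO)[C@@H](O)[C@H]1O` carries 1-benzofuran-2-yl in place of furan-2-yl on an aromatic carbon, which adds one six-membered aromatic ring of carbon only: 1-benzofuran-2-yl in place of furan-2-yl on an aromatic carbon. For the measured compounds named here, no measured step covers this exchange. Compound 3 gives 89700 nM, so little room remains on the high side of this assay, and any new number is expected to fall lower. The expected change is a 2.0-fold lower number from compound 3 to compound 4 (0.30 log units; within the scatter), a modest one with wide uncertainty. For compound 4 the estimated value is 45000 nM, with an expected range from 12000 nM to 100000 nM.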

Compound 4, half-maximal inhibitory concentration: 22700 nM
Estimate against measurement, compound 4: 2.0-fold (0.30 log units) above, and the stated range covers the measured number.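

Adding one six-membered aromatic ring of carbon only to the furan-2-yl group gives a 4.0-fold lower number from compound 3 to compound 4 (0.60 log units; beyond the scatter) in this assay. Unlike the earlier step, which was only a floor, this one rests on two true numbers and lies beyond the scatter, so this position does respond to a change of aromatic group. The two groups have the same counts of hydrogen-bond donors and acceptors and no net charge, so what differs in this exchange is the added carbon ring.

As far as these compounds go, it remains open whether a fused ring is needed, or whether a phenyl ring or a longer chain at this position would give a similar number. Whether the same gain would appear with the other groups of compound 1 and compound 2 also cannot be read, because their values are limits: the limit of > 100000 nM in this assay, at which 2 of the 4 values shown sit.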